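Hydroxyphenyl-aminothiazole series: replacing ethoxy with fluoro

The source may hold more compounds than are shown below. What is called first, only, known or untested is meant among the compounds shown, and "the series" means these compounds.

Measured compounds:
compound 1, `Oc1cccc(Nc2nc(-c3ccc(Cl)cc3)cs2)c1`: 5600 nM
compound 2, `CC(=O)c1ccc(Nc2nc(-c3ccc(F)cc3)cs2)cc1`: 4900 nM
compound 3, `CCOc1ccc(-c2csc(Nc3ccc(O)cc3)n2)cc1`: 600 nM

All three numbers come from an assay on isolated protein for inhibition of Polyunsaturated fatty acid 5-lipoxygenase (Homo sapiens), with stated times of 15 min and 10 min; on this read-out lower numbers stand for stronger inhibition and higher numbers for weaker inhibition. Compound 3 stands lowest of the three, and its gap to compound 2 and to compound 1 lies beyond the usual scatter in each case, so compound 3 is the most potent of the measured set. Compound 1 and compound 2 sit close to each other, and nothing further is said of their order.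

Compound 4, `Oc1ccc(Nc2nc(-c3ccc(F)cc3)cs2)cc1`, has not been measured. It keeps the shared core and the hydroxyphenylamino part of compound 3 and differs at one place on the other ring: fluoro in place of ethoxy on an aromatic carbon, on an aromatic carbon of a six-membered aromatic ring of carbon only, para to a large group. Among the compounds with values here, no measured pair in the set shows this single change on its own, so the size of the step rests on judgement. Compound 2 carries the fluoro group on the same ring but with a different amino-side substituent, and its value offers no clean comparison.

In this assay the step from compound 3 to compound 4 is expected to be a loss, a 3.3-fold higher number from compound 3 to compound 4 (0.52 log units; beyond the scatter), moderate in size. Compound 4 is estimated at 2000 nM, with a plausible range from 600 nM to 7000 nM.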

Compound 4, half-maximal inhibitory concentration: 700 nM
The estimate for compound 4 lay 2.9-fold (0.46 log units) above the measured number; the range from low to high includes it.
By their numbers in this assay, from the lowest: compounds 3 and 4 (each within the scatter of the next); then compounds 2 and 1 (each within the scatter of the next).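

In this assay, within the data shown here, fluoro in place of ethoxy on an aromatic carbon, para to a large group, gives a 1.2-fold higher number from compound 3 to compound 4 (0.07 log units; within the scatter): this is the first clean reading of the change, and at this position the two groups cannot be told apart. With the fluoro group held constant, hydroxy in place of acetyl on an aromatic carbon of the other ring gives a 7.0-fold lower number from compound 2 to compound 4 (0.85 log units; beyond the scatter), so among these two single-place steps only the change on the hydroxyphenylamino side lies beyond the scatter. Nothing available here accounts for either step.

The compounds shown leave open how far this tolerance extends: whether a longer chain such as butoxy, a dimethylamino group or a carboxylic acid at the ethoxy position would stay level with compound 3 and compound 4 in this assay remains unknown. They also leave open whether the hydroxy group can give way to an amine or a methoxy group on its ring without a step of the size seen from acetyl, since only acetyl has been compared with it in a single-place step.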